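This account rests on a few compounds, and the source may have more. Where it says the series, first, only, none or still open, it means among the compounds named here.

Among the measured compounds shown here, in a functional assay on MDA-MB-231 cells (Homo sapiens) for cytotoxicity, read by MTT assay, with a stated time of 72 h (on this read-out higher numbers stand for weaker inhibition and lower numbers for stronger inhibition), compound 1 `O=C(CN1CCN(c2nnc(Cc3ccncc3)c3ccccc23)CC1)Nc1cccc(F)c1` gives 4.4 nM, the lowest of the three numbers so far. Compound 3 `Cc1cccc(Cl)c1NC(=O)CN1CCN(c2nnc(Cc3ccccc3)c3ccccc23)CC1` gives 3920 nM and compound 2 `Cc1ccccc1NC(=O)CN1CCN(c2nnc(Cc3ccccc3)c3ccccc23)CC1` gives 17300 nM, so both lie far above compound 1, beyond the scatter.

Compound 4 `O=C(CN1CCN(c2nnc(Cc3ccncc3)c3ccccc23)CC1)Nc1cc(C(F)(F)F)ccc1Cl` is not yet measured. It differs from compound 1 as follows: 2-chloro-5-(trifluoromethyl)phenyl in place of 3-fluorophenyl on an amide-type nitrogen.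

For the measured compounds named here, only one measured step bears on this change: a 4.4-fold lower number from compound 2 to compound 3 (0.64 log units; beyond the scatter), a modest step for chloro in place of hydrogen on an aromatic carbon. Going by the values given here, its guidance is weak, since compounds 2 and 3 also differ from compound 1 elsewhere in the structure, and no measured pair tests the trifluoromethyl group or the loss of the fluorine. Compound 1 at 4.4 nM sits far below the other two values, so a move upward seems more likely than a further drop.

The expected step is a 6.8-fold higher number from compound 1 to compound 4 (0.83 log units; beyond the scatter), toward a higher number, though with wide uncertainty. For compound 4 the estimated value is 30 nM, with an expected range of 3 nM to 600 nM.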

Compound 4, half-maximal inhibitory concentration: 3.7 nM
Beside the measured number, compound 4's estimate is 8.1-fold (0.91 log units) above it; low and high end bracket the measured number.
By their numbers in this assay, from the lowest: compounds 4 and 1 (each within the scatter of the next); then compound 3; then compound 2.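

In this assay, among the compounds shown here, the step of a 1.2-fold lower number from compound 1 to compound 4 (0.08 log units; within the scatter) is the first measured change made on the core of compound 1 itself, and it is confined to the group on the amide-type nitrogen. Exchanging 3-fluorophenyl for 2-chloro-5-(trifluoromethyl)phenyl, which has the higher heavy-atom count, leaves the read-out within the scatter, so this position accepts both substituted phenyl groups on this core without a measurable difference. No measurement available here accounts for the two groups reading alike.

Chloro and trifluoromethyl enter together in compound 4, so the contribution of each alone stays open. Also open, on these data alone, is whether this position would hold the same level with a phenyl ring bearing an amine or a carboxylic acid, or with a simple alkyl chain in place of the phenyl ring.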